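Moving from 3,4-Dichlorophenyl to 3,5-Dichlorophenyl on a Shared Core

The source may report more compounds than this note shows. Statements on the series, on what has been measured and on what is new or still open speak of the compounds shown alone.

In a functional assay on MDA-MB-231 cells (Homo sapiens) for antiproliferative activity, read by MTT assay, with a stated time of 48 h (on this read-out higher numbers stand for weaker inhibition and lower numbers for stronger inhibition), compound 1 `O=C(/C=C/c1ccc(O)cc1)Nc1cc2c(Nc3ccc(Cl)c(Cl)c3)ncnc2s1` gives 1980 nM as its half-maximal inhibitory concentration. Compound 2 `COc1ccc(/C=C/C(=O)Nc2cc3c(Nc4ccc(Cl)c(Cl)c4)ncnc3s2)cc1` gives 16600 nM in this assay and holds the higher of the two numbers, which means the weaker inhibition of the pair. For the measured compounds named here, the one measured step is an 8.4-fold higher number from compound 1 to compound 2 (0.92 log units; beyond the scatter) for methyl in place of hydrogen on an oxygen on an aromatic ring.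

The change to compound 3 `COc1ccc(/C=C/C(=O)Nc2cc3c(Nc4cc(Cl)cc(Cl)c4)ncnc3s2)cc1` is 3,5-dichlorophenyl in place of 3,4-dichlorophenyl on a nitrogen on an aromatic ring with 3,5-dichlorophenyl in place of 3,4-dichlorophenyl on a nitrogen on an aromatic ring. Going by the values given here, the measured step lies at a different place, and no measured pair varies the dichlorophenyl group, so it gives no direct guide to this change. Among the compounds with values here, it shows only that one small change can move the number beyond the scatter here. No shift beyond the scatter, in either direction, is therefore expected in this assay for this change. The expected step is a 1.1-fold lower number from compound 2 to compound 3 (0.04 log units; within the scatter) with wide uncertainty. For compound 3 the estimate is 15000 nM with an expected range from 5000 nM to 45000 nM in this assay as well.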

Compound 3, half-maximal inhibitory concentration: 1970 nM
Beside the measured number, compound 3's estimate is 7.6-fold (0.88 log units) above it, and the stated range ends above it.
By their numbers in this assay, from the lowest: compounds 3 and 1 (each within the scatter of the next); then compound 2.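

The swap of 3,4-dichlorophenyl for 3,5-dichlorophenyl on the nitrogen gives an 8.4-fold lower number from compound 2 to compound 3 (0.93 log units; beyond the scatter) in this assay, so this position responds to where the two chlorines sit, although the group that leaves and the group that enters have the same heavy atoms, the same aromatic ring, and the same counts of hydrogen-bond donors and acceptors. For the compounds shown here, the earlier step concerned only the methyl on the oxygen at the other end of the molecule, so this is the first sign that the dichlorophenyl group is also a place where a single change moves the number beyond the scatter. No measured evidence bears on why this rearrangement of the same atoms has such an effect.

The compounds shown leave open whether the same swap would produce a step of similar size and direction with the hydrogen on the oxygen of compound 1 in place of the methyl. They also leave open how a plain phenyl group or a bromophenyl group on this nitrogen would compare with 3,5-dichlorophenyl on the shared core.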